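This account rests on a few compounds, and the source may have more. Where it says the series, first, only, none or still open, it means among the compounds named here.

Measured in an assay on CHO T-rex cells for antagonist activity at transient receptor potential cation channel subfamily M member 8 (Homo sapiens), read by calcium flux, with a stated time of 20 min; a lower number here means a stronger inhibitor, a higher number a weaker inhibitor:
compound 1 `C[C@H](c1ccc(F)cc1)N(Cc1cccc(C(=O)O)c1)C(=O)c1cccc(-c2ccccc2)c1` gives 837 nM
compound 2 `C[C@H](c1ccc(F)cc1)N(Cc1cccc(C(=O)O)c1)C(=O)c1ccc(Oc2ccccc2)cc1` gives only a limit, > 6160 nM
compound 3 `O=C(O)c1cccc(CN(C(=O)c2cnc3ccccc3c2)[C@H](CO)c2ccccc2)c1` gives only a limit, > 6860 nM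

Compound 3 stands at the limit of > 6860 nM in this assay, at which 1 of the 3 values shown sits, so its place among the three cannot be fixed; one further value, that of compound 2, is likewise a limit, and compound 1 alone gives a number. Compound 4 `CC[C@H](c1ccc(C)o1)N(Cc1cccc(C(=O)O)c1)C(=O)c1cnc2ccccc2c1` differs from compound 3 in one place: 1-(5-methylfuran-2-yl)propyl in place of 2-hydroxy-1-phenylethyl on an amide-type nitrogen. Since compound 3 shows only a limit, the expected step of an at least 3.8-fold lower number from compound 3 to compound 4 (0.58 log units; beyond the scatter) is judged a gain beyond the scatter, but with wide uncertainty. Compound 4 is therefore estimated at 1800 nM, within 400 nM to 8000 nM.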

Compound 4, half-maximal inhibitory concentration: 328 nM
Estimate against measurement, compound 4: 5.5-fold (0.74 log units) above; the whole stated range lies above it.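

Replacing 2-hydroxy-1-phenylethyl with 1-(5-methylfuran-2-yl)propyl on the amide-type nitrogen gives an at least 20-fold lower number from compound 3 to compound 4 (1.32 log units; beyond the scatter) in this assay. With the rest of compound 3 kept, this one substituent thus separates a limit from a measured number. Compound 3 gives a limit of the assay, not a number: the limit of > 6860 nM in this assay, at which 1 of the 4 values shown sits.

Open, as far as these compounds go, is whether the gain goes with the five-membered aromatic ring or with the loss of the hydroxy group; the two change together. From the compounds shown here alone, how an amine or a longer chain at this place would read also remains open.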